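Hydrazone swap on a shared core: chloro-phenyl to hydroxy-naphthyl

The source may report more compounds than this note shows. Statements on the series, on what has been measured and on what is new or still open speak of the compounds shown alone.

Compound 1 `CCCSc1nc(N/N=C/c2ccccc2Cl)c2nnn(Cc3ccccc3)c2n1`: 6180 nM
Compound 2 `CCCSc1nc(N/N=C(\C)c2ccc(OC)cc2)c2nnn(Cc3ccccc3)c2n1`: > 64000 nM
Compound 3 `CCCSc1nc(N/N=C(\C)c2ccccc2O)c2nnn(Cc3ccc(F)cc3)c2n1`: 21900 nM

Three compounds share one core and differ in the group hung on the hydrazone carbon. In a functional assay on ECa-109 cells (Homo sapiens) for antiproliferative activity, read by MTT assay, with a stated time of 72 h (a lower number here means a stronger inhibitor, a higher number a weaker inhibitor), compound 1 gives 6180 nM, the lowest number among the two real values; compound 3 sits at 21900 nM, a gap beyond the scatter. For compound 2 the result is only a limit, (the limit of > 64000 nM in this assay, at which 1 of the 3 values shown sits), not a number. Compound 4 `CCCSc1nc(N/N=C/c2c(O)ccc3ccccc23)c2nnn(Cc3ccccc3)c2n1` is not yet measured. It changes compound 1 by 2-hydroxynaphthalen-1-yl in place of 2-chlorophenyl on a carbon with a double bond to nitrogen. For the measured compounds named here, with no measured step of this kind to lean on, the expected step from compound 1 to compound 4 is a 1.2-fold lower number from compound 1 to compound 4 (0.09 log units; within the scatter), no change beyond the scatter. Compound 4 is therefore estimated at 5000 nM, expected between 1500 nM and 20000 nM.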

Compound 4, half-maximal inhibitory concentration: 9290 nM
The estimate for compound 4 lay 1.9-fold (0.27 log units) below the measured number; the range from low to high includes it.
By their numbers in this assay, from the lowest: compounds 1 and 4 (each within the scatter of the next); then compound 3. At a limit, above all of these: compound 2.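

Replacing 2-chlorophenyl with 2-hydroxynaphthalen-1-yl on a carbon with a double bond to nitrogen gives, in this assay, a 1.5-fold higher number from compound 1 to compound 4 (0.18 log units; within the scatter), so the two compounds cannot be told apart. This position therefore accepts a second aromatic ring and a hydroxyl group in place of the chlorine without a measurable loss of activity. Nothing measured here explains why the two groups read alike. Still open, as far as these compounds go, is how this position would respond to an amine or a carboxylic acid on the aromatic ring. A simple unsubstituted phenyl group on the same carbon would show whether either substituent matters.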